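A few compounds are considered here, and "the series" means these few. Any claim that something is new, unique, unknown or untested is made for them only; others in the source may bear on it.

Measured compounds in a functional assay (plasma) with Homo sapiens as the target; on this read-out higher numbers stand for an effect only at larger amounts of compound and lower numbers for an effect already at smaller amounts:
- compound 1 `N=C(N)NCCCC(C=O)NC(=O)C1CCCN1C(=O)C(=O)CCc1ccccc1` gives 460 nM
- compound 2 `N=C(N)NCCCC(C=O)NC(=O)C1CCCN1C(=O)C(=O)Cc1ccccc1` gives 750 nM
- compound 3 `N=C(N)NCCCC(C=O)NC(=O)C1CCCN1C(=O)C(=O)COc1ccccc1` gives 1000 nM

Compound 1 holds the lowest of the three numbers in this assay. Its neighbour is compound 2, and the step of a 1.6-fold higher number from compound 1 to compound 2 (0.21 log units; within the scatter) is within the scatter. The step of a 2.2-fold higher number from compound 1 to compound 3 (0.34 log units; beyond the scatter) is beyond the scatter, though modest, and between the other two compounds the step of a 1.3-fold higher number from compound 2 to compound 3 (0.12 log units; within the scatter) is again within the scatter.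

Compound 4 `N=C(N)NCCCC(C=O)NC(=O)C1CCCN1C(=O)C(=O)CCC1CCCCC1` is not yet measured. Against compound 1 it carries the change (cyclohexyl in place of phenyl on a saturated chain carbon, two bonds along the chain from a carbonyl carbon). Going by the values given here, none of the measured steps bears on this change: the three measured steps alter what stands between the carbonyl chain and the phenyl group, while the phenyl group itself is kept in every measured compound. The saturated ring of compound 4 is therefore untested in this series, and the spread of the measured numbers is narrow.

The expectation for compound 4 in this assay is a step of a 1.4-fold higher number from compound 1 to compound 4 (0.15 log units; within the scatter), not clearly beyond the scatter in either direction, with wide uncertainty. The estimate for compound 4 is 650 nM, with a range from 250 nM to 1700 nM.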

Compound 4, half-maximal effective concentration: 300 nM
The estimate for compound 4 lay 2.2-fold (0.34 log units) above the measured number; measured number inside the range.
By their numbers in this assay, from the lowest: compounds 4, 1, 2 and 3 (each within the scatter of the next, the first and the last beyond it).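

In this assay, a 1.5-fold lower number from compound 1 to compound 4 (0.19 log units; within the scatter), so at this place, on a saturated chain carbon two bonds along the chain from a carbonyl carbon, the one six-membered aromatic ring of compound 1 is not needed to hold the number: cyclohexyl, with the same count of heavy atoms and no hydrogen-bond donors or acceptors, gives a value that cannot be told apart from that of phenyl. The wider comparison also shifts, since a 2.5-fold lower number from compound 2 to compound 4 (0.40 log units; beyond the scatter) and a 3.3-fold lower number from compound 3 to compound 4 (0.52 log units; beyond the scatter), both beyond the scatter though modest, whereas compound 1 stood clear of compound 3 only and remained within the scatter of compound 2. No measurement on hand accounts for the aromatic and saturated rings giving such similar numbers.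

Still open, from the compounds shown here alone, is whether cyclohexyl can replace phenyl equally well on the shorter chain of compound 2 or the oxygen-linked chain of compound 3, and whether a longer chain carrying the cyclohexyl would keep the number in this range. The compounds shown also leave open how an amine or a carboxylic acid on the saturated ring would read in this assay.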